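The compounds below may be only part of what the source reports. "The series", "measured", "known", "first", "only" and "open" are said of these compounds alone.

Three compounds have been measured in an ADME assay on Vero cells (Chlorocebus sabaeus) for cytotoxicity, read by fluorescence and resazurin assay, with a stated time of 3 days; on this read-out lower numbers stand for higher toxicity in this test and higher numbers for lower toxicity in this test:

Compound 1 `CC(=O)C[C@H]1O[C@@H](On2cc(CN3C(=O)/C(=N\Nc4ccc(F)cc4)c4ccccc43)nn2)[C@H](OC(C)=O)[C@@H](OC(C)=O)[C@H]1OC(C)=O` gives 78600 nM.
Compound 2 `CC(=O)C[C@H]1O[C@@H](On2cc(CN3C(=O)/C(=N\Nc4cccc(Cl)c4)c4ccccc43)nn2)[C@H](OC(C)=O)[C@@H](OC(C)=O)[C@H]1OC(C)=O` gives 87900 nM.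
Compound 3 `O=C1/C(=N\Nc2ccc(F)cc2)c2ccccc2N1Cc1cn(O[C@@H]2O[C@H](CO)[C@H](O)[C@H](O)[C@H]2O)nn1` gives 92100 nM.

Compound 1 and compound 2 share one core, and the change between them is 3-chlorophenyl in place of 4-fluorophenyl on an amine nitrogen. In this assay this change made a 1.1-fold higher number from compound 1 to compound 2 (0.05 log units; within the scatter). Compound 3 carries a different core; the difference between the two cores is not broken down here. All three measured values lie within the scatter of one another, so no order among them can be claimed.

Compound 4 `O=C1/C(=N\Nc2cccc(Cl)c2)c2ccccc2N1Cc1cn(O[C@@H]2O[C@H](CO)[C@H](O)[C@H](O)[C@H]2O)nn1` has not yet been measured. It differs from compound 3 by 3-chlorophenyl in place of 4-fluorophenyl on an amine nitrogen, the same change as between compound 1 and compound 2, at a place worded the same in both cases. The step from compound 3 to compound 4 in this assay is expected to be small, estimated at a 1.1-fold higher number from compound 3 to compound 4 (0.04 log units; within the scatter). This expectation rests on compound 1 and compound 2, because a 1.1-fold higher number from compound 1 to compound 2 (0.05 log units; within the scatter). Compound 4 is therefore estimated to give 100000 nM in this assay, with a likely range from 50000 nM to 200000 nM.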

Compound 4, half-maximal cytotoxic concentration: 84500 nM
The estimate for compound 4 lay 1.2-fold (0.07 log units) above the measured number, within the range that was stated.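

Putting 3-chlorophenyl in place of 4-fluorophenyl on an amine nitrogen gave, in this assay, a 1.1-fold lower number from compound 3 to compound 4 (0.04 log units; within the scatter), so the swap left no readable mark on the core of compound 3. Set beside the same swap on the core of compound 1, the two steps point in opposite directions on paper but do not differ beyond what repeated measurements would produce: the same change on two cores in this assay, a 1.1-fold higher number (0.05 log units; within the scatter) from compound 1 to compound 2 and a 1.1-fold lower number (0.04 log units; within the scatter) from compound 3 to compound 4, 1.2-fold (0.09 log units) apart, within the scatter of two such steps. This shows that the swap was equally silent on both cores in this test, but with both steps inside the scatter it shows no real effect that could be said to carry over, and two pairs cannot set a rule for other cores or other assays.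

The compounds shown leave open whether a phenyl ring bearing an amine or a carboxylic acid in this place would shift the number beyond the scatter. With all four compounds so close together in this assay, they also leave open which structural features, if any, govern toxicity in this test.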